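A Trifluoromethyl Group Enters a Guanidine Series

The compounds below may be only part of what the source reports. "The series", "measured", "known", "first", "only" and "open" are said of these compounds alone.

Of the compounds shown here, two built on a shared core have been measured in a functional assay on cardiac atrium for agonist activity at histamine H2 receptor (Cavia porcellus); on this read-out lower numbers stand for lower potency and higher numbers for higher potency (the scale is a negative logarithm). Compound 1 `N=C(NCCCc1c[nH]cn1)NCCCC(c1ccccc1)c1ccccn1` gives 6.61 in this assay. Compound 2 `N=C(NCCCc1c[nH]cn1)NCCC(c1ccccc1)c1ccccn1` gives 7.39 in this assay, the higher of the two numbers, and the number for compound 1 lies beyond the usual scatter below it. Compound 3 `N=C(NCCCc1c[nH]cn1)NCCC(c1ccc(C(F)(F)F)cc1)c1ccccn1` is not yet measured. It differs from compound 2 in one place: trifluoromethyl in place of hydrogen on an aromatic carbon, the phenyl becoming a 4-(trifluoromethyl)phenyl. For the measured compounds named here, no pair of the measured compounds shows a change of this kind, so nothing among the numbers says which way this step runs. The step from compound 2 to compound 3 in this assay is expected to be a number 0.09 log units lower from compound 2 to compound 3 (within the scatter), which means no change beyond the scatter. Compound 3 is therefore estimated to give 7.3 in this assay, with a likely range from 6.6 to 8.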

Compound 3, negative logarithm of the half-maximal effective concentration: 7.76
For compound 3 the middle estimate is 0.46 log units below the measured one; low and high end bracket the measured number.
By their numbers in this assay, from the lowest: compound 1; then compound 2; then compound 3.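

In this assay the change from phenyl to 4-(trifluoromethyl)phenyl gives a number 0.37 log units higher from compound 2 to compound 3 (beyond the scatter), a modest gain, so this aromatic carbon takes a group of four heavy atoms in place of hydrogen with no loss in potency. For the compounds shown here, the earlier pair differed only in the chain, so this is the first reading of any change on the ring itself. Nothing at hand accounts for the gain.

From the compounds shown here alone, it remains open whether other groups at this position, such as a fluorine, a methoxy group or an amine, would give a step of the same direction and size, and whether trifluoromethyl would do so on another carbon of the ring. Also open, going by these compounds, is whether the gain would carry over to the longer chain of compound 1.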